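This account rests on a few compounds, and the source may have more. Where it says the series, first, only, none or still open, it means among the compounds named here.

Measured so far:
compound 1, `c1ccc(COc2ccc(OCCOCCNC3CCOC3)cc2)cc1` — 48000 nM
compound 2, `Nc1ccccc1COc1ccc(OCCOCCNC2CCCC2)cc1` — 14000 nM
compound 3, `c1ccc(COc2ccc(OCCOCCNC3CC3)cc2)cc1` — 47200 nM

In a functional assay on SK-OV-3 cells (Homo sapiens) for inhibition, read by CCK-8 assay, with a stated time of 70 h (a higher number here means a weaker inhibitor, a lower number a stronger inhibitor), compound 2 gives the lowest of the three numbers; its gap to compound 3 and to compound 1 lies beyond the scatter, so compound 2 is the most potent of the measured set. Compound 1 and compound 3 share an unsubstituted benzyl group and differ only at the amine, where the step of a 1.0-fold lower number from compound 1 to compound 3 (0.01 log units; within the scatter) is flat.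

Compound 4, `COC(=O)c1ccc(COc2ccc(OCCOCCNC3CCCC3)cc2)cc1`, is not yet measured. It keeps the pyrrolidinyl amine of compound 2 but alters the benzyl ring: 4-(methoxycarbonyl)phenyl in place of 2-aminophenyl on a saturated chain carbon bound to an oxygen on an aromatic ring. Going by the values given here, no measured step touches this ring alone, since compound 1 and compound 3 differ from compound 2 at the amine as well, so the only guidance is that the two compounds lacking the 2-aminophenyl group sit higher than compound 2 in this assay. Among the compounds with values here, the single measured step, between compound 1 and compound 3, concerns the amine and does not bear on this change. On that basis compound 4 is expected to lose part of the advantage of compound 2, with a step of a 2.1-fold higher number from compound 2 to compound 4 (0.33 log units; beyond the scatter) toward higher numbers expected. Compound 4 is estimated at 30000 nM, within a range from 10000 nM to 90000 nM.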

Compound 4, half-maximal inhibitory concentration: 6990 nM
Compound 4: middle estimate off by 4.3-fold (0.63 log units), on the high side; the measured number lies below the stated range.
By their numbers in this assay, from the lowest: compounds 4 and 2 (each within the scatter of the next); then compounds 3 and 1 (each within the scatter of the next).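

Going by these compounds alone, this position accepts very different groups: the step of a 2.0-fold lower number from compound 2 to compound 4 (0.30 log units; within the scatter) in this assay is the first measured change at this ring with the amine held constant, and it stays within the scatter. The 2-aminophenyl group, with 7 heavy atoms, 1 hydrogen-bond donor and 1 hydrogen-bond acceptor, gives way to 4-(methoxycarbonyl)phenyl, with 10 heavy atoms, 0 hydrogen-bond donors and 2 hydrogen-bond acceptors, so the number in this assay does not depend on keeping the 2-aminophenyl group or its donor. Nothing available explains why the two groups give numbers within the scatter of each other.

The compounds shown leave open how an unsubstituted phenyl group would read at this place on the amine shared by compound 2 and compound 4, which would give this ring a baseline with the amine held constant. They also leave open whether a carboxylic acid or an amide in place of the methoxycarbonyl group would keep the number within the scatter of compound 4, or whether the ester itself matters.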